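Bromo in place of trifluoromethyl on compound 3

A few compounds are considered here, and "the series" means these few. Any claim that something is new, unique, unknown or untested is made for them only; others in the source may bear on it.

In a functional assay (strain AB) with Danio rerio as the target, read by microscopy, with a stated time of 1 h (a lower number here means that less compound is needed, a higher number that more compound is needed for the effect), compound 1 `CCN1CCc2c(sc(NC(=O)Nc3ccccc3)c2C(N)=O)C1` gives only a limit, > 25000 nM. Compound 2 `CCN1CCc2c(sc(NC(=O)Nc3ccc(Cl)cc3Cl)c2C(N)=O)C1` gives 11500 nM. Going by the values given here, compound 3 `CCN1CCc2c(sc(NC(=O)Nc3ccc(C(F)(F)F)cc3)c2C(N)=O)C1` gives 2910 nM, the lowest number measured so far, and its gap to compound 2 lies beyond the scatter.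

Compound 4 `CCN1CCc2c(sc(NC(=O)Nc3ccc(Br)cc3)c2C(N)=O)C1` carries bromo in place of trifluoromethyl on an aromatic carbon.

Among the compounds with values here, two measured steps bear on this change: an at least 8.5-fold lower number from compound 1 to compound 3 (0.93 log units; beyond the scatter) with trifluoromethyl in place of hydrogen, and an at least 2.1-fold lower number from compound 1 to compound 2 (0.33 log units; beyond the scatter) with 2,4-dichlorophenyl in place of phenyl. From the compounds shown here alone, both start from the limit of > 25000 nM in this assay, at which 1 of the 3 values shown sits, so their full sizes remain open. Neither compares bromo directly with trifluoromethyl.

The substituent at this carbon is retained, so a return to the limit seen for compound 1 is not expected. With compound 2 at 11500 nM, a number between those of compound 3 and compound 2 seems most likely.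

A modest upward step is expected in this assay, a 2.2-fold higher number from compound 3 to compound 4 (0.35 log units; beyond the scatter). For compound 4 the estimated value is 6500 nM, with an expected range of 2200 nM to 18000 nM.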

Compound 4, half-maximal effective concentration: 3130 nM
Compound 4: middle estimate off by 2.1-fold (0.32 log units), on the high side; the range from low to high includes it.
By their numbers in this assay, from the lowest: compounds 3 and 4 (each within the scatter of the next); then compound 2. At a limit, above all of these: compound 1.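

In this assay, going by these compounds alone, the exchange of trifluoromethyl for bromo on this aromatic carbon gives a 1.1-fold higher number from compound 3 to compound 4 (0.03 log units; within the scatter), so the two groups are not separated at this position, a comparison the earlier compounds did not offer. Against 2,4-dichlorophenyl, the 4-bromophenyl group gives a 3.7-fold lower number from compound 2 to compound 4 (0.57 log units; beyond the scatter), which shows that a single bromo on this carbon keeps the number clearly apart from that of the dichlorinated analogue. Bromo in place of hydrogen gives an at least 7.9-fold lower number from compound 1 to compound 4 (0.90 log units; beyond the scatter), so the step seen with trifluoromethyl is not confined to that group, although this step starts from a limit and its full size stays open: the limit of > 25000 nM in this assay, at which 1 of the 4 values shown sits.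

From the compounds shown here alone, whether an amine or a carboxylic acid on this aromatic carbon would stay in the same range remains open. The shared core is the same in all compounds shown, and how changes to it would read here also remains open.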